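Three-Aryl Pyridine Series: Topoisomerase 1 Inhibition Notes

A few compounds are considered here, and "the series" means these few. Any claim that something is new, unique, unknown or untested is made for them only; others in the source may bear on it.

Measured compounds:
compound 1 `Oc1ccc(-c2cc(-c3ccccn3)nc(-c3ccccc3Cl)c2)cc1` 5.2%
compound 2 `Oc1ccc(-c2cc(-c3ccco3)nc(-c3ccccc3Cl)c2)cc1` 3.9%
compound 3 `Oc1ccc(-c2cc(-c3ccsc3)nc(-c3ccccc3Cl)c2)cc1` 4.1%

In an assay on isolated protein for inhibition of DNA topoisomerase 1 (Homo sapiens), with a stated time of 30 min, tested at 100 uM (a higher number here means a stronger effect of the compound at the concentration tested, a lower number a weaker effect), compound 1 gives 5.2%, compound 2 gives 3.9% and compound 3 gives 4.1%. All three numbers sit close together and none of the steps between them leaves the scatter: a number 1.3 percentage points lower from compound 1 to compound 2 (within the scatter), a number 1.1 percentage points lower from compound 1 to compound 3 (within the scatter), a number 0.2 percentage points higher from compound 2 to compound 3 (within the scatter). Compound 3 is therefore indistinguishable from both neighbours on this assay, with compound 2 the nearer and compound 1 the farther of the two.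

Compound 4 `Oc1ccc(-c2cc(-c3cccnc3)nc(-c3ccccc3Cl)c2)cc1` is the next compound to be measured. Its change from compound 3 is pyridin-3-yl in place of thiophen-3-yl on an aromatic carbon. Going by the values given here, the steps that bear on this are the exchange of one heteroaryl group for another at the same position, seen in the step from compound 1 to compound 3 and in the step from compound 2 to compound 3, both of which stayed within the scatter. On that basis no step beyond the scatter is expected in this assay for compound 4: the expected step is a number 0.4 percentage points higher from compound 3 to compound 4 (within the scatter). The estimate for compound 4 is 4.5%, with an expected range from -4% to 13%.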

Compound 4, a percentage reported as inhibition, at one concentration (the size of the read-out at that concentration, not a potency): 0.9%
The estimate for compound 4 lay 3.6 percentage points above the measured number, and the stated range covers the measured number.
By their numbers in this assay, from the lowest: compounds 4, 2, 3 and 1 (each within the scatter of the next).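

In this assay, the four heteroaryl groups on the aromatic carbon next to the ring nitrogen cannot be told apart. Neither a change of ring size, from thiophen-3-yl to pyridin-3-yl (a number 3.2 percentage points lower from compound 3 to compound 4 (within the scatter)), nor an exchange of pyridin-2-yl for pyridin-3-yl (a number 4.3 percentage points lower from compound 1 to compound 4 (within the scatter)) leaves the scatter, and the same holds for furan-2-yl to pyridin-3-yl (a number 3 percentage points lower from compound 2 to compound 4 (within the scatter)). No measurement is available that would explain these numbers.

Open, on these data alone, is whether an amine, a carboxylic acid or a longer chain at this position would give a step beyond the scatter. Also open, as far as these compounds go, is whether any change to the 2-chlorophenyl or 4-hydroxyphenyl group would do so.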